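The source may hold more compounds than are shown below. What is called first, only, known or untested is meant among the compounds shown, and "the series" means these compounds.

Three compounds set the scene. Compound 1 `CCC(COC)N(C)c1nc(C)nc2c1nnn2-c1ccc(C(C)C)cc1Br` gives 11.2 nM in an in vitro assay on 293-EBNA cells for binding affinity to corticotropin-releasing factor receptor 1 (Homo sapiens); on this read-out lower numbers stand for stronger inhibition and higher numbers for weaker inhibition. Compound 2 `CCCCC(CC)Nc1nc(C)nc2c1nnn2-c1c(C)cc(C)cc1C` gives 7.6 nM in this assay, and compound 3 `CCCCN(CC)c1nc(C)nc2c1nnn2-c1c(Br)cc(OC)cc1OC` gives 3 nM in this assay. Among these three numbers compound 1 has the highest; the gap to compound 2 lies within the usual scatter of repeated measurements, so the two cannot be told apart, whereas compound 3 sits clearly lower, beyond the scatter.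

Compound 4 `COCCNc1nc(C)nc2c1nnn2-c1ccc(C(C)C)cc1Br` has not been measured. It comes from compound 1 by a single change (a group of 5 heavy atoms (3 carbon, 1 nitrogen, 1 oxygen; no ring) in place of a group of 8 heavy atoms (6 carbon, 1 nitrogen, 1 oxygen; no ring), on an aromatic carbon). The shared core of compound 1 and its brominated aryl ring stay the same; only the chain on the amine nitrogen shrinks from eight heavy atoms to five and gains one hydrogen-bond donor.

Among the compounds with values here, every compound measured so far carries a longer chain at this position, including compound 2 at 7.6 nM and compound 3 at 3 nM. A shorter chain is therefore expected to cost affinity: the step of a 4.5-fold higher number from compound 1 to compound 4 (0.65 log units; beyond the scatter) is estimated as a rise in the inhibition constant beyond the scatter. Compound 4 is expected to land near 50 nM, with a range from 15 nM to 200 nM.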

Compound 4, inhibition constant: 242 nM
Beside the measured number, compound 4's estimate is 4.8-fold (0.68 log units) below it, outside the stated range (above it).
By their numbers in this assay, from the lowest: compound 3; then compounds 2 and 1 (each within the scatter of the next); then compound 4.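

Within the data shown here, with the shared core and the brominated aryl ring held constant, this is the first pair here that differs in only one place, so the effect in this assay can be assigned to the group on this aromatic carbon. Replacing the 8-heavy-atom group of compound 1 with (2-methoxyethyl)amino gives a 22-fold higher number from compound 1 to compound 4 (1.33 log units; beyond the scatter), a large step well beyond the scatter, which shows that the inhibition constant is highly sensitive to the group at this position. No measurement shown here explains this loss of affinity.

The change alters two counted features at once: the group falls from 8 heavy atoms to 5, and it goes from 0 hydrogen-bond donors to 1, so the compounds shown cannot say which of these matters or whether both do. Still open, from the compounds shown here alone, is how a tertiary amine carrying a methyl group and a 2-methoxyethyl chain on the nitrogen would compare, since it would keep 0 hydrogen-bond donors, and how a longer chain on the secondary amine of compound 4 would compare, since it would keep the hydrogen-bond donor.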